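Methyl for chloro on the phenoxy ring of compound 2

This account rests on a few compounds, and the source may have more. Where it says the series, first, only, none or still open, it means among the compounds named here.

The measured compounds:
compound 1, `Cc1nn(C)c(Oc2ccccc2F)c1/C=N\CCCCCCOc1cc2oc(=O)cc(C)c2cc1Cl`: in a functional assay on HepG2 cells (Homo sapiens) for antiproliferative activity, read by MTT assay, with a stated time of 72 h (on this read-out lower numbers stand for stronger inhibition and higher numbers for weaker inhibition), compound 1 reports only a limit, > 25000 nM.
compound 2, `Cc1nn(C)c(Oc2ccc(Cl)cc2)c1/C=N\CCCCCCOc1cc2oc(=O)cc(C)c2cc1Cl`: in this assay compound 2 gives 2960 nM.

For the measured compounds named here, compound 2 thus holds the only actual number in this assay; the other value is a limit, as the limit of > 25000 nM in this assay, at which 1 of the 2 values shown sits, states. Going by the values given here, the single measured step, an at least 8.4-fold lower number from compound 1 to compound 2 (0.92 log units; beyond the scatter), concerns the same phenoxy ring, but it exchanges both the group and its place on the ring, so it speaks only loosely to the change at hand.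

Compound 3, `Cc1ccc(Oc2c(/C=N\CCCCCCOc3cc4oc(=O)cc(C)c4cc3Cl)c(C)nn2C)cc1`, differs from compound 2 by methyl in place of chloro on an aromatic carbon. Among the compounds with values here, no measured step isolates this exchange. The halogen-to-methyl swap keeps the group at the same place on the ring and keeps the heavy-atom count, so the account expects at most a small movement in this assay: compound 3 is estimated at 4000 nM, with a range from 1500 nM to 12000 nM. The expected step is a 1.4-fold higher number from compound 2 to compound 3 (0.13 log units; within the scatter), which is not beyond the scatter.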

Compound 3, half-maximal inhibitory concentration: 20700 nM
Compound 3: the middle estimate sits 5.2-fold (0.71 log units) below what was measured; measured number outside the range, above it.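

At this place on the phenoxy ring, chloro and methyl are not interchangeable in this assay: the exchange gives a 7.0-fold higher number from compound 2 to compound 3 (0.84 log units; beyond the scatter), although one heavy atom leaves and one enters, and neither group carries a hydrogen-bond donor, a hydrogen-bond acceptor or a net charge. The earlier step changed both the group and its place on the ring, whereas this one keeps the place fixed, so it ties the lower number of compound 2 to the chloro group itself. Compound 1 reports only a limit, and the comparison with it gives an at least 1.2-fold lower number from compound 1 to compound 3 (0.08 log units; that floor lies within the scatter), which does not separate the 4-methylphenyl compound from the 2-fluorophenyl compound: the limit of > 25000 nM in this assay, at which 1 of the 3 values shown sits.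

The values shown do not say why chloro and methyl part so clearly, nor whether the lower number is particular to chloro or would also hold for fluoro, bromo, methoxy or trifluoromethyl at this place. Going by these compounds, with only 4-chlorophenyl and 4-methylphenyl compared directly, it also remains open whether chloro would keep this advantage at another place on the ring.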